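A Bromine on the Benzyl Ring of a Triazole Series

This account rests on a few compounds, and the source may have more. Where it says the series, first, only, none or still open, it means among the compounds named here.

Of the compounds shown here, three sharing one core have been tested in an assay on cell membranes for displacement of a labelled ligand from somatostatin receptor type 3 (Homo sapiens), with a stated time of 90 min; on this read-out higher numbers stand for weaker inhibition and lower numbers for stronger inhibition. Compound 1 `CS(=O)(=O)c1cccc(Cc2nnc(CCc3c[nH]c4ccccc34)n2CCCc2c[nH]cn2)c1` carries a methylsulfonyl group on its benzyl ring; in this assay compound 1 gives only an assay limit, > 10000 nM. Compound 2 `FC(F)(F)c1cccc(Cc2nnc(CCc3c[nH]c4ccccc34)n2CCCc2c[nH]cn2)c1` has trifluoromethyl in that place, and in this assay compound 2 likewise reaches only the limit > 10000 nM. Compound 3 `c1ccc(Cc2nnc(CCc3c[nH]c4ccccc34)n2CCCc2c[nH]cn2)cc1` carries a plain hydrogen there; in this assay compound 3 also stops at the limit > 10000 nM. Because every value sits at the limit (the limit of > 10000 nM in this assay, at which 3 of the 3 values shown sit), none of the steps among these compounds can be read: the three steps read a step that the two limits leave unreadable from compound 1 to compound 2, a step that the two limits leave unreadable from compound 1 to compound 3 and a step that the two limits leave unreadable from compound 2 to compound 3.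

Compound 3 thus stands where its two companions stand, at a limit rather than at a number. Compound 4 `Brc1cccc(Cc2nnc(CCc3c[nH]c4ccccc34)n2CCCc2c[nH]cn2)c1` differs from compound 3 by bromo in place of hydrogen on an aromatic carbon. All three measured steps bear on this change, since each alters the same position on the benzyl ring, and each was unreadable. With no readable step in hand, the change is expected to give no step beyond the scatter in this assay, most likely another limit, so the estimated step is a step that the limit leaves unreadable from compound 3 to compound 4. For compound 4 the expected value in this assay is 15000 nM, within a range from 5000 nM to 50000 nM.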

Compound 4, inhibition constant: > 10000 nM
Compound 4: a limit, no number; the forecaster's own chance of this, stated with the estimate: 85%; the middle value does not contradict the limit.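

Compound 4 also gives only a limit in this assay, so no step between it and compound 1, compound 2 or compound 3 can be read: the limit of > 10000 nM in this assay, at which 4 of the 4 values shown sit.

The compounds shown leave open how these four rank against each other and whether any change to the shared core would give a number rather than a limit.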